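From Hydroxymethyl to Hydroxyethyl on Compound 3

The source may report more compounds than this note shows. Statements on the series, on what has been measured and on what is new or still open speak of the compounds shown alone.

Within the data shown here, in an ADME assay on cells (Hepatocyte, Rattus norvegicus, strain Wistar) for pharmacokinetics, read by LC-MS, with a stated time of 90 min, tested at 1 uM (a lower number here means slower removal, a higher number faster removal of the compound), compound 3 `COc1cc(C(=O)N2CC(C)OCC2CO)cc2nc(N[C@H](C)c3cccc(Cl)c3)oc12` gives 15.5 mL/min/kg, the lowest of the three numbers so far. Compound 1 `COc1cc(C(=O)N2CC[C@H](O)[C@@H](C)C2)cc2nc(NCc3cccc(Cl)c3)oc12` gives 36.7 mL/min/kg and compound 2 `COc1cc(C(=O)N2CC(C)(CCO)OC[C@H]2C)cc2nc(N[C@H](C)c3cccc(Cl)c3)oc12` gives 58.3 mL/min/kg, and both gaps to compound 3 lie beyond the usual scatter.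

Compound 4 `COc1cc(C(=O)N2C[C@H](C)OC[C@@H]2CCO)cc2nc(N[C@H](C)c3cccc(Cl)c3)oc12` differs from compound 3 in one group on a carbonyl carbon, where 5-(2-hydroxyethyl)-2-methylmorpholin-4-yl takes the place of 5-(hydroxymethyl)-2-methylmorpholin-4-yl: 5-(2-hydroxyethyl)-2-methylmorpholin-4-yl in place of 5-(hydroxymethyl)-2-methylmorpholin-4-yl on a carbonyl carbon.

Among the measured compounds shown here, only one measured step bears on this change: a 3.8-fold lower number from compound 2 to compound 3 (0.58 log units; beyond the scatter). There, 5-(hydroxymethyl)-2-methylmorpholin-4-yl replaced 2-(2-hydroxyethyl)-2,5-dimethylmorpholin-4-yl. For the measured compounds named here, the group that left in that step is not the one entering here, and no measured pair isolates the longer chain alone, so the step is only a loose guide.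

Given the higher number of the hydroxyethyl-bearing compound 2 at 58.3 mL/min/kg, a small rise is expected in this assay, smaller than that step and perhaps no larger than the scatter. The expected change is a 1.6-fold higher number from compound 3 to compound 4 (0.21 log units; within the scatter). For compound 4 the estimated clearance is 25 mL/min/kg, with an expected range of 13 mL/min/kg to 48 mL/min/kg.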

Compound 4, clearance: 45 mL/min/kg
Compound 4: the middle estimate sits 1.8-fold (0.26 log units) below what was measured; measured number inside the range.
By their numbers in this assay, from the lowest: compound 3; then compounds 1, 4 and 2 (each within the scatter of the next).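

Lengthening the chain from hydroxymethyl to 2-hydroxyethyl, which takes the group on the carbonyl carbon from 9 to 10 heavy atoms, gives a 2.9-fold higher number from compound 3 to compound 4 (0.46 log units; beyond the scatter) in this assay, so this small change at this place is enough to move the clearance beyond the scatter. The other new step, a 1.3-fold lower number from compound 2 to compound 4 (0.11 log units; within the scatter), lies within the scatter, so 5-(2-hydroxyethyl)-2-methylmorpholin-4-yl and 2-(2-hydroxyethyl)-2,5-dimethylmorpholin-4-yl cannot be told apart here, and among these three compounds only the hydroxymethyl compound stands apart from the others, with the lower number. Nothing measured here gives a reason for the rise.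

Compound 4 carries 2 defined stereocentres in the entering group, while none are printed for the group that leaves compound 3, so the compounds shown cannot separate the effect of chain length from that of a defined arrangement in space. As far as these compounds go, it also remains open whether a 3-hydroxypropyl chain or a carboxylic acid in the same place would carry the number further up or bring it back down.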